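The source may report more compounds than this note shows. Statements on the series, on what has been measured and on what is new or still open speak of the compounds shown alone.

Measured so far in a functional assay; on this read-out higher numbers stand for weaker inhibition and lower numbers for stronger inhibition:
- compound 1 `COc1ccc(C2C(C#N)=C(N)OC(c3c[nH]c4ccccc34)=C2C#N)cc1OC` gives 867 ug/mL as a number
- compound 2 `Cc1ccccc1C1C(C#N)=C(N)OC(c2c[nH]c3ccccc23)=C1C#N` gives > 1000 ug/mL as a limit
- compound 3 `Cc1ccc(C2C(C#N)=C(N)OC(c3c[nH]c4ccccc34)=C2C#N)cc1` gives > 1000 ug/mL as a limit

Compound 3 gives > 1000 ug/mL as a limit, not a number. It stands at the limit of > 1000 ug/mL in this assay, at which 2 of the 3 values shown sit, and so has no exact place in the series.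

The next compound, compound 4 `N#CC1=C(N)OC(c2c[nH]c3ccccc23)=C(C#N)C1c1ccccc1Cl`, has not yet been measured in this assay and carries 2-chlorophenyl in place of 4-methylphenyl on a saturated ring carbon. The counted difference is 2-chlorophenyl in place of 4-methylphenyl on a saturated ring carbon and nothing else in the structure changes.

Within the data shown here, three measured steps bear on this position. Leaving 3,4-dimethoxyphenyl gave an at least 1.1-fold higher number from compound 1 to compound 2 (0.06 log units; that floor lies within the scatter) and an at least 1.1-fold higher number from compound 1 to compound 3 (0.06 log units; that floor lies within the scatter) as its two results, so neither floor goes beyond the scatter. Moving between the two methylphenyl groups gave a step that the two limits leave unreadable from compound 2 to compound 3 and so shows no size at all. No swap at this position has yet shown a change beyond the scatter, so none is expected here. The expected size is a number no higher from compound 3 to compound 4 (the limit leaves the size open) as an estimate only. For compound 4 the estimated value is 1000 ug/mL, with an expected range from 450 ug/mL to 2200 ug/mL and a fair chance of another limit.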

Compound 4, half-maximal inhibitory concentration: > 1000 ug/mL
Compound 4 gave a limit, no number; the forecaster's own chance of this, stated with the estimate: 60%; the middle value sits exactly at the limit.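

In this assay compound 4 gives > 1000 ug/mL, which is a limit and not a number. What is new is that a halogen-bearing group, 2-chlorophenyl, now joins the two methylphenyl groups on this saturated ring carbon, and putting it in place of 3,4-dimethoxyphenyl gave an at least 1.1-fold higher number from compound 1 to compound 4 (0.06 log units; that floor lies within the scatter), so this swap also shows no change beyond the scatter. The steps that link compound 4 to compound 2 and compound 3 cannot be read, because the values at both ends of each step are limits: the limit of > 1000 ug/mL in this assay, at which 3 of the 4 values shown sit.

Only compound 1 has an exact value so far, so the compounds shown leave open whether any group on this carbon can bring the value clearly below the limit, and how far the true values of compound 2, compound 3 and compound 4 lie beyond it. Also open, on these data alone, is where a phenyl ring carrying an amine or a carboxylic acid would fall, or a longer chain in place of the ring.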